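Phenyl to 4-methylphenyl: expectation for compound 4

The compounds below may be only part of what the source reports. "The series", "measured", "known", "first", "only" and "open" are said of these compounds alone.

Compound 3 `O=C1C2ON=C(c3cn(-c4ccccc4)nc3-c3ccc(Cl)cc3)C2C(=O)N1c1ccccc1` stands highest of the three numbers in a functional assay on the whole organism (Abdomen, strain Swiss albino) with Mus musculus as the target, with stated times of 10 min and 5 min, at a dose of 15 mg/kg by the oral route; on this read-out lower numbers stand for a weaker effect and higher numbers for a stronger effect at the one dose given: compound 3 gives 23.9%, while compound 2 `CCOc1ccc(-c2nn(-c3ccccc3)cc2C2=NOC3C(=O)N(c4ccccc4)C(=O)C23)cc1` gives 12.2% and compound 1 `O=C1C2ON=C(c3cn(-c4ccccc4)nc3-c3ccc(Br)cc3)C2C(=O)N1c1ccccc1` gives 2.75%. The steps of a number 21.2 percentage points higher from compound 1 to compound 3 (beyond the scatter) and a number 11.7 percentage points higher from compound 2 to compound 3 (beyond the scatter) lie beyond the scatter, whereas a number 9.5 percentage points higher from compound 1 to compound 2 (within the scatter) stays within it. Compound 4 `Cc1ccc(N2C(=O)C3ON=C(c4cn(-c5ccccc5)nc4-c4ccc(Cl)cc4)C3C2=O)cc1` differs from compound 3 by methyl in place of hydrogen on an aromatic carbon. All three measured steps exchange the bromo, ethoxy and chloro groups on the other aromatic ring, so none of them bears on this change and there is no direct guide. The expectation is a step of a number 1.9 percentage points lower from compound 3 to compound 4 (within the scatter) in this assay, not beyond the scatter. Compound 4 is therefore estimated at 22%, with a range from 8% to 38%.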

Compound 4, a percentage reported as activity, at one dose (the size of the read-out at that dose, not a potency): 22.8%
Compound 4: middle estimate off by 0.8 percentage points, on the low side, and the stated range covers the measured number.
By their numbers in this assay, from the lowest: compounds 1 and 2 (each within the scatter of the next); then compounds 4 and 3 (each within the scatter of the next).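

Among these compounds, the step phenyl to 4-methylphenyl gives a number 1.1 percentage points lower from compound 3 to compound 4 (within the scatter) in this assay, and it is the only reading on this aromatic ring, as the earlier steps all exchanged groups on the other one. At this one dose, methyl on an aromatic carbon para to a large group leaves compound 3 and compound 4 indistinguishable. No measurement available bears on the reason for this.

As far as these compounds go, whether an amine, a carboxylic acid or a longer chain at this place would also leave the read-out within the scatter remains open. Also open, from the compounds shown here alone, is whether methyl here would behave alike with bromo or ethoxy on the other ring.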